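A few compounds are considered here, and "the series" means these few. Any claim that something is new, unique, unknown or untested is made for them only; others in the source may bear on it.

Measured compounds:
- compound 1, `O=C(NCCCNc1nccc(-c2c(-c3cccc(F)c3)nc3sccn23)n1)c1ccc(F)cc1`: > 20000 nM
- compound 2, `O=C(NCCNc1nccc(-c2c(-c3cccc(F)c3)nc3sccn23)n1)c1ccc(C(F)(F)F)cc1`: 9260 nM

The two measured compounds share a core and differ in the chain and in the group on its outer amine nitrogen. In a functional assay on SK-MEL-28 cells (Homo sapiens) for cytotoxicity, read by MTT assay (a higher number here means a weaker inhibitor, a lower number a stronger inhibitor), compound 1 is reported only as a limit, > 20000 nM, so no number is known for it. That limit is the one described by the limit of > 20000 nM in this assay, at which 1 of the 2 values shown sits. For the measured compounds named here, compound 2 is the only one of the pair with a number: in this assay compound 2 gives 9260 nM, a weak value in itself. Going by the values given here, no step between measured compounds is available, since the two differ in more than one place.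

Compound 3, `O=S(=O)(NCCCNc1nccc(-c2c(-c3cccc(F)c3)nc3sccn23)n1)c1ccccc1`, is not yet measured. It keeps the chain of compound 1 and differs from it only at the amine nitrogen: phenylsulfonyl in place of (4-fluorophenyl)carbonyl on an amine nitrogen. Among the compounds with values here, with compound 1 sitting at the limit and compound 2 only weakly active, there is no measured step on which to build an expectation of a gain. The step of a number no higher from compound 1 to compound 3 (the limit leaves the size open) is therefore expected to be none beyond the scatter, and compound 3 is expected to give about 20000 nM in this assay, somewhere between 6000 nM and 60000 nM, quite possibly again only as a limit.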

Compound 3, half-maximal inhibitory concentration: 6850 nM
Estimate against measurement, compound 3: 2.9-fold (0.47 log units) above; low and high end bracket the measured number.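

Putting phenylsulfonyl in place of (4-fluorophenyl)carbonyl on the amine nitrogen gives, in this assay, an at least 2.9-fold lower number from compound 1 to compound 3 (0.46 log units; beyond the scatter). This is the only step shown between compounds that differ in one place, and it shows that the group on this nitrogen can by itself change the read-out while the chain and the shared core stay the same. Compound 3 now has a number, 6850 nM. The true size of the step stays open because compound 1 is reported only as a limit and not as a number: the limit of > 20000 nM in this assay, at which 1 of the 3 values shown sits.

The change swaps the carbonyl for a sulfonyl and removes the fluorine in one move, and the compounds shown cannot separate these two parts; a (4-fluorophenyl)sulfonyl group on the same chain would be needed to do that. They also leave open whether a methylsulfonyl group, a longer chain or a phenylsulfonyl group on the chain of compound 2 would give a lower number still in this assay.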